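Series notes: lipophilicity of compounds 1 to 4

A few compounds are considered here, and "the series" means these few. Any claim that something is new, unique, unknown or untested is made for them only; others in the source may bear on it.

Measured so far:
compound 1, `O=C(Nc1cc2cccccc-2c1)c1cccnc1`: 1.3
compound 2, `COC(=O)c1ccc2ccc(C(=O)N(C)C)c-2cc1`: 2.3
compound 3, `COC(=O)c1ccc2ccc(C(=O)c3ccccc3)c-2cc1`: 4.8

In a physicochemical assay for lipophilicity, read by HPLC, measured as octanol-water partition, at pH 2 (on this read-out lower numbers stand for lower lipophilicity and higher numbers for higher lipophilicity), compound 3 stands highest of the three numbers. Among the measured compounds shown here, the one comparable step is a number 2.50 log units higher from compound 2 to compound 3 (beyond the scatter), phenyl in place of dimethylamino on a carbonyl carbon. Compound 1 lies further off still; its value and that of compound 3 differ by more than the scatter.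

Compound 4, `COC(=O)c1ccc2c(C(=O)c3ccccc3)cc(C(=O)c3ccccc3)c-2cc1`, differs from compound 3 in one place: benzoyl in place of hydrogen on an aromatic carbon. For the measured compounds named here, no measured step adds a benzoyl where hydrogen stood; the only step in hand exchanged one carbonyl substituent for another and was large. A rise beyond the scatter is expected, a number 1.50 log units higher from compound 3 to compound 4 (beyond the scatter), though smaller than that step. Compound 4 is estimated at 6.3, between 5.5 and 7.2.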

Compound 4, distribution coefficient: 5.6
Beside the measured number, compound 4's estimate is 0.70 log units above it; low and high end bracket the measured number.
By their numbers in this assay, from the lowest: compound 1; then compound 2; then compound 3; then compound 4.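

In this assay, a benzoyl in place of hydrogen on this aromatic carbon of a five-membered aromatic ring, two ring bonds from the ring atom that bears a benzoyl group, gives a number 0.80 log units higher from compound 3 to compound 4 (beyond the scatter). Among the compounds shown here, this is the first step that puts a group where hydrogen stood, and it is smaller than a number 2.50 log units higher from compound 2 to compound 3 (beyond the scatter). Nothing on hand accounts for the size of this step.

From the compounds shown here alone, whether an amine, a carboxylic acid or an acetyl on the same aromatic carbon would give a step of similar size remains open. So does the size of the step for a benzoyl on another aromatic carbon of the shared core.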